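This account rests on a few compounds, and the source may have more. Where it says the series, first, only, none or still open, it means among the compounds named here.

Measured compounds in an assay on L cells for inhibition of Protein-serine O-palmitoleoyltransferase porcupine (Mus musculus), read by reporter gene assay, with a stated time of 24 h; on this read-out higher numbers stand for an effect only at larger amounts of compound and lower numbers for an effect already at smaller amounts:
compound 1 `O=C(CSc1nc2c(c(=O)n1-c1ccccc1)SCC2)Nc1ccc(-c2ccoc2)cn1`, 1.5 nM
compound 2 `O=C(CSc1nc2c(c(=O)n1-c1ccccc1)SCC2)Nc1ccc(-c2ccncc2)cc1`, 3 nM
compound 3 `O=C(CSc1nc2c(c(=O)n1-c1ccccc1)SCC2)Nc1nc2ccc(C(F)(F)F)cc2s1`, 40 nM

Compound 1 has the lowest number of the three in this assay. Compound 2 lies within the scatter of it, so no order between compound 1 and compound 2 can be read. Compound 3 stands clearly higher than compound 1, beyond the scatter.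

Compound 4 `O=C(CSc1nc2c(c(=O)n1-c1ccccc1)SCC2)Nc1ccc(-c2cccnc2)cn1` differs from compound 1 in one place: pyridin-3-yl in place of furan-3-yl on an aromatic carbon. Among the compounds with values here, no measured pair shows this kind of change. Since the change swaps one small aromatic ring for another of the same kind, with the acceptor count unchanged, the step from compound 1 to compound 4 is expected to stay within the scatter, in either direction, a 1.3-fold higher number from compound 1 to compound 4 (0.12 log units; within the scatter). Compound 4 is therefore estimated at 2 nM in this assay, with a range from 0.7 nM to 7 nM.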

Compound 4, half-maximal effective concentration: 1 nM
Compound 4: the middle estimate sits 2.0-fold (0.30 log units) above what was measured; low and high end bracket the measured number.
By their numbers in this assay, from the lowest: compounds 4, 1 and 2 (each within the scatter of the next, the first and the last beyond it); then compound 3.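

In this assay, pyridin-3-yl in place of furan-3-yl gives a 1.5-fold lower number from compound 1 to compound 4 (0.18 log units; within the scatter) at this aromatic carbon para to a large group. Within the data shown here, this is the first single-place comparison, and it shows that a six-membered aromatic ring with 1 nitrogen and a five-membered aromatic ring with 1 oxygen read alike here. Nothing available explains this result.

On these data alone, whether this position keeps its number with a non-aromatic group, such as an amine, a carboxylic acid or a longer alkyl chain, stays open. As far as these compounds go, the effect of changing the other parts of compound 1 one at a time also stays open.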